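The source may hold more compounds than are shown below. What is called first, only, known or untested is meant among the compounds shown, and "the series" means these compounds.

Measured so far:
compound 1 `COc1ccccc1N1CCN(CCCNC(=O)CN2CCCCC2=O)CC1` – 10000 nM
compound 2 `CC(C)Oc1ccccc1N1CCN(CCNC(=O)CN2CCCCCC2=O)CC1` – 3540 nM
compound 3 `CC(C)Oc1cc(F)ccc1N1CCN(CCNC(=O)CN2CCCCC2=O)CC1` – 10000 nM

In an assay on COS cells for binding affinity to Alpha-1B adrenergic receptor (Homo sapiens) (on this read-out higher numbers stand for weaker inhibition and lower numbers for stronger inhibition), compound 1 gives 10000 nM. On this read-out compound 1 stands level with compound 3, the two together at the highest number of the three; compound 2 sits at a lower number, and its gap to compound 1 lies beyond the scatter. Within the data shown here, no pair of these three differs in one place only, so no single step is counted among the measured compounds.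

Compound 4 `CC(C)Oc1ccccc1N1CCN(CCCNC(=O)CN2CCCCC2=O)CC1` has not been measured in this assay. It differs from compound 1 by isopropyl in place of methyl on an oxygen on an aromatic ring, read one bond further out as methoxy to isopropoxy. Compounds 2 and 3 both carry the isopropoxy group, but each also differs from compound 1 elsewhere, so their values give no clean guide. For compound 4 a small move to a lower number, or none beyond the scatter, is expected, a 1.7-fold lower number from compound 1 to compound 4 (0.22 log units; within the scatter). The estimate for compound 4 in this assay is 6000 nM, within 2500 nM to 15000 nM.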

Compound 4, inhibition constant: 10000 nM
Compound 4: the middle estimate sits 1.7-fold (0.22 log units) below what was measured; the measured number falls inside the stated range.
By their numbers in this assay, from the lowest: compound 2; then compounds 1, 3 and 4 (each within the scatter of the next).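

In this assay, isopropyl in place of methyl on an oxygen on an aromatic ring leaves the number where it stood (no change at the digits printed from compound 1 to compound 4 (within the scatter)). Among these compounds, this is the first clean reading of the change: compounds 2 and 3 also carry isopropoxy but differ from compound 1 elsewhere, whereas here the rest of the core of compound 1 is held fixed and methoxy and isopropoxy read alike. No measured property in hand bears on this result.

Still open, going by these compounds, is whether a different group on that oxygen, such as ethyl, cyclopropylmethyl or a plain hydroxyl in place of the whole alkoxy group, would move the number. Also open, on these data alone, is whether methoxy to isopropoxy reads the same on a core carrying a longer chain.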